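Replacing the Chloromethoxyphenyl Amide with a Thiazole Amide

The source may report more compounds than this note shows. Statements on the series, on what has been measured and on what is new or still open speak of the compounds shown alone.

Three measured compounds share one core and differ only in the group attached to a urea-type nitrogen. Compound 1 `COc1ccc(Cl)cc1C(=O)NCCC1CCN(S(=O)(=O)NC(=O)NC2CCCCC2)CC1` gives 25% in a functional assay on the whole organism (blood) with Rattus norvegicus as the target, with stated times of 24 h and 1 h, at a dose of 5 mg/kg by the intraperitoneal route (on this read-out higher numbers stand for a stronger effect at the one dose given and lower numbers for a weaker effect), the lowest of the three numbers, though its gap to compound 2 is within the scatter. Compound 2 `COc1ccc(Cl)cc1C(=O)NCCC1CCN(S(=O)(=O)NC(=O)NC[C@@H]2C[C@@H]3CC[C@@H]2O3)CC1` gives 30%, and the step of a number 5 percentage points higher from compound 1 to compound 2 (within the scatter) is within the scatter. Compound 3 `COc1ccc(Cl)cc1C(=O)NCCC1CCN(S(=O)(=O)NC(=O)NN2CCCCCC2)CC1` gives 36%; the step of a number 11 percentage points higher from compound 1 to compound 3 (beyond the scatter) is beyond the scatter, but modest.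

Compound 4 `O=C(NC1CCCCC1)NS(=O)(=O)N1CCC(CCNC(=O)c2cscn2)CC1` has not yet been measured. It differs from compound 1 at the other end of the molecule: 1,3-thiazol-4-yl in place of 5-chloro-2-methoxyphenyl on a carbonyl carbon. Among the measured compounds shown here, none of the measured steps touches this part of the structure, so none of them bears directly on the change; they only show that this series has so far moved over a narrow span. For compound 4 the expected step is a number 3 percentage points lower from compound 1 to compound 4 (within the scatter), with no direction beyond the scatter. The estimate for compound 4 is 22%, with a range from 5% to 40%.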

Compound 4, a percentage reported as activity, at one dose (the size of the read-out at that dose, not a potency): 23%
Compound 4: the middle estimate sits 1 percentage points below what was measured; the measured number falls inside the stated range.
By their numbers in this assay, from the lowest: compounds 4, 1, 2 and 3 (each within the scatter of the next, the first and the last beyond it).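

In this assay, among the compounds shown here, placing 1,3-thiazol-4-yl on the carbonyl carbon instead of 5-chloro-2-methoxyphenyl gives a number 2 percentage points lower from compound 1 to compound 4 (within the scatter), the first reading at this end of the molecule. For this one pair, a six-membered aromatic ring of carbon only, carrying chlorine and methoxy, can give way to a five-membered aromatic ring with hetero atoms, and a group with fewer heavy atoms can replace a larger one, with no step beyond the scatter at this single dose. Nothing available explains why the two compounds read alike.

Still open, from the compounds shown here alone, is whether 1,3-thiazol-4-yl gives a similar reading when azepan-1-yl replaces cyclohexyl on the other side of the molecule. Also open, going by these compounds, is what an unsubstituted phenyl or a pyridine ring would give on the same carbonyl carbon, and whether a read-out at one dose conceals differences in potency.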